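A chloro substituent carried over to a second core

This account rests on a few compounds, and the source may have more. Where it says the series, first, only, none or still open, it means among the compounds named here.

Compound 1 `O=S(=O)(/C=C/c1ccccn1)c1ccccc1F` and compound 2 `O=S(=O)(/C=C/c1ccc(Cl)cn1)c1ccccc1F` share one core, while compound 3 `O=S(=O)(/C=C/c1ccccn1)c1cccc(Cl)c1` and the unmeasured compound 4 `O=S(=O)(/C=C/c1ccc(Cl)cn1)c1cccc(Cl)c1` share another; the difference between the two cores is not broken down here. In an assay on U2OS cells for activation of nuclear factor erythroid 2-related factor 2 (Homo sapiens), read by beta-arrestin recruitment, with a stated time of 6 h (on this read-out lower numbers stand for an effect already at smaller amounts and higher numbers for an effect only at larger amounts of compound), compound 1 gives 1050 nM, compound 2 gives 1040 nM and compound 3 gives 1430 nM. The change from compound 1 to compound 2 is chloro in place of hydrogen on an aromatic carbon, and it produced a 1.0-fold lower number from compound 1 to compound 2 (0.00 log units; within the scatter). The change from compound 3 to compound 4 is chloro in place of hydrogen on an aromatic carbon, the same change on the other core. The step expected here is a 1.0-fold lower number from compound 3 to compound 4 (0.01 log units; within the scatter), resting on compound 1 and compound 2 because their step was a 1.0-fold lower number from compound 1 to compound 2 (0.00 log units; within the scatter). In this assay compound 4 is therefore estimated at 1400 nM, with a likely range from 700 nM to 2800 nM.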

Compound 4, half-maximal effective concentration: 1510 nM
The estimate for compound 4 lay 1.1-fold (0.03 log units) below the measured number; the measured number falls inside the stated range.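

In this assay, chloro in place of hydrogen on an aromatic carbon gave a 1.1-fold higher number from compound 3 to compound 4 (0.02 log units; within the scatter). Set beside the earlier step, the change reads alike on both cores: the same change on two cores in this assay, a 1.0-fold lower number (0.00 log units; within the scatter) from compound 1 to compound 2 and a 1.1-fold higher number (0.02 log units; within the scatter) from compound 3 to compound 4, 1.1-fold (0.03 log units) apart, within the scatter of two such steps. Going by these compounds alone, this shows that, for these two pairs, the change carried over in the sense that neither step goes beyond the scatter, but it covers only two cores and one place on the ring, and it does not show that a step of real size would carry over in the same way.

The compounds shown leave open whether another group at this place on the ring, such as an amine, a nitrile or a methoxy group, would give a step beyond the scatter. They also leave open whether the chloro would read alike on any further core.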